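From methyl(phenyl)amino to pyrrolidin-1-yl on a shared core

The source may report more compounds than this note shows. Statements on the series, on what has been measured and on what is new or still open speak of the compounds shown alone.

In an ADME assay on MT4 cells (Homo sapiens) for cytotoxicity, read by MTT assay, with a stated time of 4 days (a lower number here means that less compound is tolerated, a higher number that more compound is tolerated), compound 1 (`CCCN(C)c1nc(Cc2c(F)cccc2F)c(C)c(=O)[nH]1`) gives > 81000 nM as a limit of the assay, not a number. Compound 2 (`Cc1c(Cc2c(F)cccc2F)nc(N(C)c2ccccc2)[nH]c1=O`) gives > 73000 nM and this too is only a limit, so compound 2 has no exact number to start from.

Compound 3 (`Cc1c(Cc2c(F)cccc2F)nc(N2CCCC2)[nH]c1=O`) has pyrrolidin-1-yl in place of methyl(phenyl)amino on an aromatic carbon. Among the compounds with values here, the one measured step that bears on this change is a step that the two limits leave unreadable from compound 1 to compound 2 and it puts phenyl in place of propyl on a nitrogen on an aromatic ring. It offers no size to carry over.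

No step beyond the usual scatter is therefore expected in this assay and the expected change is a step that the limit leaves unreadable from compound 2 to compound 3 with no firm direction. Compound 3 is estimated at 80000 nM with an expected range from 35000 nM to 130000 nM and the result may well be a limit again.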

Compound 3, half-maximal cytotoxic concentration: > 82000 nM
Compound 3: only a limit was reported; the forecaster's own chance of this, stated with the estimate: 75%; at least 1.0-fold (0.01 log units) between middle value and limit.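

In this assay, within the data shown here, compound 3 gives > 82000 nM, which is a limit and not a number, and compound 1 and compound 2 also have only limits, so no step among them can be read. The compounds shown leave open whether swapping these groups on the shared core changes cytotoxicity at all.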